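This account rests on a few compounds, and the source may have more. Where it says the series, first, only, none or still open, it means among the compounds named here.

Working notes on the series.

Compound 1 `O=C(Nc1cc(C(F)(F)F)cc(C(F)(F)F)c1)c1ccc(-c2ccccc2)cc1O` carries a phenyl group on its core; compound 2 `O=C(Nc1ccc(Cl)cc1Cl)c1ccc2cccnc2c1O` and compound 3 `O=C(Nc1ccc(Cl)cc1)c1ccc2cccnc2c1O` share a different core, and the difference between the two cores is not broken down here. In a functional assay on Jurkat cells (Homo sapiens) for cytotoxicity, read by luminescence and CellTiter-Glo, with a stated time of 3 days (on this read-out higher numbers stand for weaker inhibition and lower numbers for stronger inhibition), compound 1 gives 1240 nM, compound 2 gives 430 nM and compound 3 gives 510 nM. Compound 1 stands highest of the three numbers.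

Compound 4 `O=C(Nc1cc(C(F)(F)F)cc(C(F)(F)F)c1)c1cc(Cl)c(-c2ccccc2)cc1O` is still to be measured in this assay. Its change from compound 1 is chloro in place of hydrogen on an aromatic carbon. The change from compound 3 to compound 2 is chloro in place of hydrogen on an aromatic carbon, and it gave a 1.2-fold lower number from compound 3 to compound 2 (0.07 log units; within the scatter). The two changes are the same kind of change, not the same: in compound 4 the chloro group sits ortho to a phenyl group, meta to a large group and para to a hydroxy group, while in compound 2 it sits ortho to a large group and meta to a chloro group.

The estimate for compound 4 rests on compound 2 having given a 1.2-fold lower number from compound 3 to compound 2 (0.07 log units; within the scatter): a step of a 1.2-fold lower number from compound 1 to compound 4 (0.09 log units; within the scatter) is expected, with the number expected near 1000 nM and likely between 450 nM and 2400 nM.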

Compound 4, half-maximal inhibitory concentration: 540 nM
For compound 4 the middle estimate is 1.9-fold (0.27 log units) above the measured one; measured number inside the range.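

On the core of compound 1, chloro in place of hydrogen on an aromatic carbon gives in this assay a 2.3-fold lower number from compound 1 to compound 4 (0.36 log units; beyond the scatter), and set beside the earlier step on the other core, the two steps cannot be told apart: the same change on two cores in this assay, a 1.2-fold lower number (0.07 log units; within the scatter) from compound 3 to compound 2 and a 2.3-fold lower number (0.36 log units; beyond the scatter) from compound 1 to compound 4, 1.9-fold (0.29 log units) apart, within the scatter of two such steps. Within the data shown here, the two pairs are therefore compatible with a step of similar size on both cores, but only the step on the core of compound 1 stands clear of the scatter, so the step on the other core gives it no independent support. Nor do they show that the change transfers as such, since there are only two pairs, the chloro group sits in a different place in each, and no cause for either step can be drawn from them.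

The compounds shown leave open whether a bromo, methoxy or amino group in the place of the chloro group of compound 4 would give a step of similar size. Also open, from the compounds shown here alone, is whether that chloro group would give the same step with a carboxylic acid in place of one trifluoromethyl group.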